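Methyl for bromo on the triazolyl aryl of compound 1

The compounds below may be only part of what the source reports. "The series", "measured", "known", "first", "only" and "open" are said of these compounds alone.

For the measured compounds named here, compound 1 `C=C1C(=O)[C@]23C[C@@]1(O)CC[C@H]2c1ccc(OS(=O)(=O)c2ccc(C)cc2)c(C)c1[C@@H]3Cn1cc(-c2ccc(Br)cc2)nn1` is the one member of this set with a number rather than a limit: in a functional assay on MCF7 cells (Homo sapiens) for cytotoxicity, read by MTT assay, with a stated time of 4 days (a lower number here means a stronger inhibitor, a higher number a weaker inhibitor), compound 1 gives 250 nM. Compound 2 `C=C1C[C@]23C[C@@]1(O)CC[C@H]2c1cc(Br)c(O)c(C)c1[C@@H]3Cn1cc(-c2ccc(OC)cc2)nn1` reaches only a limit in this assay, namely > 20000 nM. Compound 3 `COc1ccc(-c2cn(C[C@H]3c4c(ccc(OS(=O)(=O)c5ccc(C)cc5)c4C)[C@@H]4CC[C@@]5(C)C[C@]43CC5=O)nn2)cc1` likewise stops at a limit in this assay, namely > 20000 nM. Going by the values given here, the set is dominated by the limit of > 20000 nM in this assay, at which 2 of the 3 values shown sit, so no step between measured compounds can be sized. Compound 4 `C=C1C(=O)[C@]23C[C@@]1(O)CC[C@H]2c1ccc(OS(=O)(=O)c2ccc(C)cc2)c(C)c1[C@@H]3Cn1cc(-c2ccc(C)cc2)nn1` differs from compound 1 by methyl in place of bromo on an aromatic carbon. Among the compounds with values here, with no measured step of this kind to lean on, a small step is expected, a 1.6-fold higher number from compound 1 to compound 4 (0.20 log units; within the scatter), not clearly beyond the scatter, if anything toward a weaker inhibitor. Compound 4 is estimated at 400 nM in this assay, with a range from 150 nM to 1500 nM.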

Compound 4, half-maximal inhibitory concentration: 320 nM
For compound 4 the middle estimate is 1.3-fold (0.10 log units) above the measured one; the range from low to high includes it.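

This gives the series its first sized step, in this assay: a 1.3-fold higher number from compound 1 to compound 4 (0.11 log units; within the scatter). On the aromatic carbon para to a large group, methyl in place of bromo leaves the number within the scatter, so bromine is not required at this position for a measured value in this assay. The result speaks only to this exchange of two single-atom groups.

The remaining steps cannot be read: the limit of > 20000 nM in this assay, at which 2 of the 4 values shown sit. As far as these compounds go, whether an amine or a carboxylic acid at this position would keep such a value remains open.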